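Swapping the aryl group on the ring nitrogen

The source may report more compounds than this note shows. Statements on the series, on what has been measured and on what is new or still open speak of the compounds shown alone.

Compound 3 `O=C(Nc1ccc(Oc2ccnc3[nH]ccc23)c(F)c1)c1cn(-c2ccc(Br)cc2)c2ccccc2c1=O` gives 710 nM in a functional assay on HepG2 cells (Homo sapiens) for inhibition, read by MTT assay, with a stated time of 72 h (a higher number here means a weaker inhibitor, a lower number a stronger inhibitor), the lowest of the three numbers measured. Compound 2 `O=C(Nc1ccc(Oc2ccnc3[nH]ccc23)c(F)c1)c1cn(-c2ccccc2)c2ccccc2c1=O` gives 760 nM in this assay, and compound 1 `O=C(Nc1ccc(Oc2ccnc3[nH]ccc23)cc1)c1cn(-c2ccc(F)c(Cl)c2)c2ccccc2c1=O` gives 1120 nM, a number close to that of compound 3. Going by the values given here, the one single change measured at this nitrogen is a 1.1-fold lower number from compound 2 to compound 3 (0.03 log units; within the scatter). Compound 4 `O=C(Nc1ccc(Oc2ccnc3[nH]ccc23)c(F)c1)c1cn(-c2ccc(F)c(Cl)c2)c2ccccc2c1=O` carries 3-chloro-4-fluorophenyl in place of 4-bromophenyl on an aromatic nitrogen. Compound 1 also bears the 3-chloro-4-fluorophenyl group and differs from compound 4 in another part of the molecule. Because a 1.1-fold lower number from compound 2 to compound 3 (0.03 log units; within the scatter) changed little, compound 4 is expected to show a 1.2-fold higher number from compound 3 to compound 4 (0.08 log units; within the scatter), nothing beyond the scatter. The estimate for compound 4 in this assay is 850 nM, with a range from 400 nM to 1800 nM.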

Compound 4, half-maximal inhibitory concentration: 3390 nM
For compound 4 the middle estimate is 4.0-fold (0.60 log units) below the measured one; measured number outside the range, above it.
By their numbers in this assay, from the lowest: compounds 3, 2 and 1 (each within the scatter of the next); then compound 4.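

In this assay the aryl group on the ring nitrogen does matter: 3-chloro-4-fluorophenyl brings a 4.8-fold higher number from compound 3 to compound 4 (0.68 log units; beyond the scatter) and a 4.5-fold higher number from compound 2 to compound 4 (0.65 log units; beyond the scatter), although bromo in place of hydrogen on that aryl ring changed nothing beyond the scatter. The added fluorine elsewhere in the molecule also counts, with a 3.0-fold higher number from compound 1 to compound 4 (0.48 log units; beyond the scatter), a change seen with this aryl group only. No measurement here explains these steps. Open, as far as these compounds go, is how 3-chlorophenyl or 4-fluorophenyl alone would compare, and how this nitrogen would respond to an aryl ring carrying an amine or a carboxylic acid.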